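Two weak ureas and a ring swap on the shared core

The source may hold more compounds than are shown below. What is called first, only, known or untested is meant among the compounds shown, and "the series" means these compounds.

Compound 1 `O=C(Nc1ccccc1)Nc1nc(NC2CC2)cc(Sc2c[nH]c3ccccc23)n1` — 7860 nM
Compound 2 `Cc1cc(Cl)ccc1NC(=O)Nc1nc(Sc2c[nH]c3ccccc23)cc(N2CCCC2)n1` — 9440 nM

In a functional assay on MDA-MB-231 cells (Homo sapiens) for inhibition, with a stated time of 72 h (on this read-out lower numbers stand for stronger inhibition and higher numbers for weaker inhibition), compound 1 gives 7860 nM and compound 2 gives 9440 nM. The two numbers lie within the usual scatter of one another, so the data do not separate compound 1 from compound 2; both sit at the weak end of what this assay resolves. Compound 3 `Cc1cc(Cl)ccc1NC(=O)Nc1nc(NC2CC2)cc(Sc2c[nH]c3ccccc23)n1` has not yet been measured. It keeps the urea of compound 2 and changes one place on the shared core: cyclopropylamino in place of pyrrolidin-1-yl on an aromatic carbon. For the measured compounds named here, that same cyclopropylamino group is already present in compound 1, which pairs it with a different urea, so no measured pair isolates this single change on its own. With both measured compounds close together, a step from compound 2 to compound 3 no larger than the scatter is expected, in either direction. The estimate for compound 3 is 7500 nM, with a likely range from 2500 nM to 22000 nM, which corresponds to an expected step of a 1.3-fold lower number from compound 2 to compound 3 (0.10 log units; within the scatter).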

Compound 3, half-maximal inhibitory concentration: 14600 nM
Compound 3: middle estimate off by 1.9-fold (0.29 log units), on the low side, within the range that was stated.
By their numbers in this assay, from the lowest: compounds 1, 2 and 3 (each within the scatter of the next).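

In this assay, a measured pair now isolates this position: with the urea held fixed, placing cyclopropylamino, with 1 hydrogen-bond donor, where pyrrolidin-1-yl has 0 gives a 1.5-fold higher number from compound 2 to compound 3 (0.19 log units; within the scatter) and so does not separate the two groups. A second pair isolates the urea, as 4-chloro-2-methylphenyl in place of phenyl on the amide-type nitrogen, with cyclopropylamino held fixed, gives a 1.9-fold higher number from compound 1 to compound 3 (0.27 log units; within the scatter) and again leaves the two compounds unseparated. Within these three compounds, neither exchange moves the read-out beyond the usual scatter, and no outside measurement bears on why.

The compounds shown leave open whether a quite different group on this aromatic carbon, such as morpholin-4-yl or a longer chain ending in a dimethylamino group, would produce a step beyond the scatter. They also leave open what the chlorine and the methyl each contribute on the urea's phenyl ring, as these two groups enter together and a phenyl ring carrying only one of them would be needed to tell them apart.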